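The source may hold more compounds than are shown below. What is called first, only, known or untested is meant among the compounds shown, and "the series" means these compounds.

Measured compounds in an ADME assay on Vero cells (Chlorocebus sabaeus) for cytotoxicity; a higher number here means a weaker inhibitor, a lower number a stronger inhibitor:
compound 1 `CC(C)(C)N1C(=O)c2cccnc2C1=O` gives 33000 nM
compound 2 `CC(C)(C)N1C(=O)c2nccnc2C1=O` gives 32000 nM
compound 3 `CCN1C(=O)c2nccnc2C1=O` gives a limit, stated below

Compound 1 and compound 2 sit within the scatter of each other. How the two cores differ is not broken down here. In this assay compound 3 gives > 100000 nM, which is a limit of the assay. The step of an at least 3.1-fold higher number from compound 2 to compound 3 (0.49 log units; beyond the scatter) is ethyl in place of tert-butyl on an amide-type nitrogen in a ring; the value reached is the limit of > 100000 nM in this assay, at which 1 of the 3 values shown sits.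

Compound 4 `CCN1C(=O)c2cccnc2C1=O` is not yet measured. It differs from compound 1 by ethyl in place of tert-butyl on an amide-type nitrogen in a ring, the same change as between compound 2 and compound 3, at the same place. Set beside the measured step, the step of a 3.3-fold higher number from compound 1 to compound 4 (0.52 log units; beyond the scatter) is expected to be of like size, resting on compound 1 at 33000 nM and on an at least 3.1-fold higher number from compound 2 to compound 3 (0.49 log units; beyond the scatter). Compound 4 is therefore estimated at 110000 nM, expected between 50000 nM and 300000 nM, with a limit reading likely.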

Compound 4, half-maximal inhibitory concentration: > 100000 nM
Compound 4 was reported as a limit; the forecaster's own chance of this, stated with the estimate: 65%; the middle value is on the limit's open side.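

In this assay ethyl in place of tert-butyl on the amide-type nitrogen gives an at least 3.0-fold higher number from compound 1 to compound 4 (0.48 log units; beyond the scatter). The direction of the change carries from one core to the other, and on each core the step lies beyond the scatter: the same change on two cores in this assay, an at least 3.1-fold higher number (0.49 log units; beyond the scatter) from compound 2 to compound 3 and an at least 3.0-fold higher number (0.48 log units; beyond the scatter) from compound 1 to compound 4; the limit leaves it open whether they differ. Whether the step has the same size on both cores is not shown, since both ethyl compounds end at a limit: the limit of > 100000 nM in this assay, at which 2 of the 4 values shown sit.

Only tert-butyl and ethyl are shown on this nitrogen, so the compounds give no trend across substituents. Where a longer chain, or a chain ending in an amine or a carboxylic acid, would fall on either core in this assay remains open.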